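The source may report more compounds than this note shows. Statements on the series, on what has been measured and on what is new or still open speak of the compounds shown alone.

Compound 1 `N=C(NCc1ccc(O)cc1)[C@@H]1CCC(=O)N1Cc1ccccc1`: 37.6%
Compound 2 `N=C(NCc1ccc(O)cc1)[C@@H]1CCC(=O)N1Cc1ccc([N+](=O)[O-])cc1`: 34.5%
Compound 3 `COc1ccc(CN2C(=O)CC[C@H]2C(=N)NCc2ccccc2)cc1`: 17.9%

In a functional assay on SH-SY5Y cells (Homo sapiens) for cytotoxicity, read by MTT assay, with stated times of 8 h, 30 min and 12 h, tested at 5 uM (a lower number here means a weaker effect, a higher number a stronger effect of the compound at the concentration tested), compound 3 gives 17.9%, the lowest of the three numbers, beyond the scatter below both compound 1 and compound 2. Compound 4 `COc1ccc(CN2C(=O)CC[C@H]2C(=N)NCc2ccc(O)cc2)cc1` differs from compound 3 by hydroxy in place of hydrogen on an aromatic carbon. Within the data shown here, no measured step isolates this change: the only measured step, a number 3.1 percentage points lower from compound 1 to compound 2 (within the scatter), concerns a different change and lies within the scatter. Compound 1 and compound 2 carry the same hydroxy and sit higher than compound 3, but they differ from it elsewhere as well, so the hydroxy cannot be credited with that gap. A modest rise is therefore expected, and a number 7.1 percentage points higher from compound 3 to compound 4 (within the scatter) may still fall within the scatter. Compound 4 is estimated at 25%, between 12% and 40%.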

Compound 4, a percentage reported as activity, at one concentration (the size of the read-out at that concentration, not a potency): 26.6%
Beside the measured number, compound 4's estimate is 1.6 percentage points below it, and the stated range covers the measured number.
By their numbers in this assay, from the lowest: compounds 3, 4, 2 and 1 (each within the scatter of the next, the first and the last beyond it).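

Taken alone, hydroxy in place of hydrogen gives a number 8.7 percentage points higher from compound 3 to compound 4 (within the scatter) and so shows no change that can be told from the scatter in this assay at this position. With the 4-hydroxybenzyl group held fixed, methoxy in place of nitro gives a number 7.9 percentage points lower from compound 2 to compound 4 (within the scatter) on the other benzyl group. Methoxy in place of hydrogen there gives a number 11 percentage points lower from compound 1 to compound 4 (beyond the scatter) and is the only one of these steps to pass the scatter.

From the compounds shown here alone, whether an amine or a carboxylic acid in place of the hydroxy would shift the number remains open. No measurement here offers a cause for any of these steps.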